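Dropping a Methoxy Group: Cytotoxicity on Vero Cells

This account rests on a few compounds, and the source may have more. Where it says the series, first, only, none or still open, it means among the compounds named here.

Three compounds have so far been examined in an ADME assay on Vero cells (Chlorocebus sabaeus) for cytotoxicity; a higher number here means that more compound is tolerated, a lower number that less compound is tolerated. Compound 1 `COc1ccc(-c2nc3cc([N+](=O)[O-])ccc3[nH]2)c(OC)c1OC` carries three methoxy groups, and in this assay compound 1 reaches only a limit of the assay, > 100000 nM. Compound 3 `COc1ccc(-c2nc3cc([N+](=O)[O-])ccc3[nH]2)c(OC)c1` likewise gives a limit in this assay, > 100000 nM. Compound 2 `COc1cc(OC)cc(-c2nc3cc(C(F)(F)F)ccc3[nH]2)c1` also returns a limit, > 100000 nM. All three values are therefore limits rather than numbers, as the limit of > 100000 nM in this assay, at which 3 of the 3 values shown sit, records. The change from compound 1 to compound 3 is hydrogen in place of methoxy on an aromatic carbon and its size is a step that the two limits leave unreadable from compound 1 to compound 3.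

Compound 4 `COc1cccc(-c2nc3cc(C(F)(F)F)ccc3[nH]2)c1` is not yet measured. It differs from compound 2 by hydrogen in place of methoxy on an aromatic carbon, the same kind of change as that from compound 1 to compound 3, though here the place is meta to a large group and meta to a methoxy group rather than ortho to two methoxy groups and meta to a large group. How the core of compound 2 differs from the core of compound 1 is not broken down here.

Going by the values given here, the expected step is a number no higher from compound 2 to compound 4 (the limit leaves the size open), resting on (the limit of > 100000 nM in this assay, at which 3 of the 3 values shown sit), at which every value so far sits. Compound 4 is thus expected to give 100000 nM in this assay, most likely again as a limit.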

Compound 4, half-maximal cytotoxic concentration: > 100000 nM
Compound 4 gave a limit, no number; the forecaster's own chance of this, stated with the estimate: 85%; the middle value lies on the limit itself.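

In this assay compound 4 gives > 100000 nM as a limit of the assay, not a number. Compound 2 stands at a limit as well, so no step can be read between compound 2 and compound 4. The compounds shown leave open whether removing a methoxy group changes the tolerated concentration at all, since none of them yields a number: the limit of > 100000 nM in this assay, at which 4 of the 4 values shown sit.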